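Trimming One Methoxy from the Carbonyl-Side Ring

The source may hold more compounds than are shown below. What is called first, only, known or untested is meant among the compounds shown, and "the series" means these compounds.

Compound 1, `COc1cc(-c2cc(/C=C/C(=O)c3ccc(N)cc3)[nH]n2)cc(OC)c1OC`, gives 5440 nM in a functional assay on OVCAR-4 cells (Homo sapiens) for inhibition, read by sulforhodamine B assay, with a stated time of 48 h; on this read-out higher numbers stand for weaker inhibition of growth and lower numbers for stronger inhibition of growth.
Compound 2, `COc1cc(-c2cc(/C=C/C(=O)c3ccc(Cl)c(Cl)c3)[nH]n2)cc(OC)c1OC`, gives 50900 nM in this assay.
Compound 3, `COc1ccc(C(=O)/C=C/c2cc(-c3cc(OC)c(OC)c(OC)c3)n[nH]2)cc1OC`, gives 16600 nM in this assay.

Among these three numbers, compound 3 stands second highest: one of the measured steps that reach it is a 3.1-fold higher number from compound 1 to compound 3 (0.48 log units; beyond the scatter), and the other is a 3.1-fold lower number from compound 2 to compound 3 (0.49 log units; beyond the scatter). The step to compound 4, `COc1ccc(C(=O)/C=C/c2cc(-c3cc(OC)c(OC)c(OC)c3)n[nH]2)cc1`, is hydrogen in place of methoxy on an aromatic carbon. For the measured compounds named here, none of the measured steps makes this same change; each of them, including a 9.4-fold higher number from compound 1 to compound 2 (0.97 log units; beyond the scatter), swaps the whole ring on the carbonyl carbon rather than removing a single methoxy. Going by the values given here, what they show is only that altering this ring shifts the number modestly, in either direction. Among the compounds with values here, with no closer precedent, the step from compound 3 to compound 4 is expected to be small, a 1.1-fold lower number from compound 3 to compound 4 (0.04 log units; within the scatter), with the direction uncertain. Compound 4 is therefore estimated at 15000 nM in this assay, within a range from 4000 nM to 60000 nM.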

Compound 4, concentration for total growth inhibition: 8320 nM
Compound 4: middle estimate off by 1.8-fold (0.26 log units), on the high side, and the stated range covers the measured number.
By their numbers in this assay, from the lowest: compounds 1, 4 and 3 (each within the scatter of the next, the first and the last beyond it); then compound 2.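

In this assay the step of a 2.0-fold lower number from compound 3 to compound 4 (0.30 log units; within the scatter) shows that taking away the methoxy ortho to a methoxy group leaves the number inside the usual scatter, so 3,4-dimethoxyphenyl and 4-methoxyphenyl cannot be told apart on this read-out. The step of a 1.5-fold higher number from compound 1 to compound 4 (0.18 log units; within the scatter) is also within the scatter and places methoxy where compound 1 has amino, whereas the step of a 6.1-fold lower number from compound 2 to compound 4 (0.79 log units; beyond the scatter) lies beyond it, so 3,4-dichlorophenyl stands clearly apart from 4-methoxyphenyl. Nothing available here explains why these numbers fall as they do.

Going by these compounds, whether the remaining methoxy matters stays open, and a plain phenyl ring, or a hydroxyl or a fluorine atom in its place, would address that. These compounds also leave open how an ethoxy group would behave at the position emptied in compound 4.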